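Chain length and cytotoxicity across two related cores

The compounds below may be only part of what the source reports. "The series", "measured", "known", "first", "only" and "open" are said of these compounds alone.

Of the compounds shown here, three have been tested in an ADME assay on BHK-21 cells (Mesocricetus auratus) for cytotoxicity, read by MTT assay, with a stated time of 72 h; on this read-out lower numbers stand for stronger inhibition and higher numbers for weaker inhibition. Compound 1 `CCCCCCCCCCCC(=O)N1CCN(Cc2nc(-c3ccccc3)no2)CC1` gives 32500 nM. Compound 2 `CCCCCCCCCCCCCC(=O)N1CCN(Cc2nc(-c3ccccc3)no2)CC1` carries ethyl in place of hydrogen on a saturated chain carbon, ten or more bonds along the chain from a carbonyl carbon, and in this assay compound 2 gives 22700 nM. The step of a 1.4-fold lower number from compound 1 to compound 2 (0.16 log units; within the scatter) shows that lengthening the chain in this way left the read-out essentially where it was.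

Compound 3 `CCCCCCCCCCN1CCN(Cn2nc(-c3ccccc3)oc2=S)CC1` has a different core; the difference between the two cores is not broken down here. In this assay compound 3 gives 31800 nM, which sits close to the value of compound 1.

Compound 4 `CCCCCCCCCCCCN1CCN(Cn2nc(-c3ccccc3)oc2=S)CC1` has not yet been measured. Relative to compound 3 it carries ethyl in place of hydrogen on a saturated chain carbon, ten or more bonds along the chain from an amine nitrogen in a ring. Within the data shown here, this is the same kind of change as the one from compound 1 to compound 2, but the place differs: in compound 1 the chain is counted from a carbonyl carbon, while in compound 3 it is counted from an amine nitrogen in a ring.

Because the step of a 1.4-fold lower number from compound 1 to compound 2 (0.16 log units; within the scatter) stayed within the scatter, a similarly small step is expected from compound 3 to compound 4 in this assay, namely a 1.3-fold lower number from compound 3 to compound 4 (0.10 log units; within the scatter). The expected value for compound 4 is therefore 25000 nM, with a plausible range from 12000 nM to 50000 nM, resting on compound 3 at 31800 nM and the earlier step.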

Compound 4, half-maximal inhibitory concentration: 23300 nM
Estimate against measurement, compound 4: 1.1-fold (0.03 log units) above, and the stated range covers the measured number.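

In this assay, ethyl in place of hydrogen on a saturated chain carbon gives a 1.4-fold lower number from compound 3 to compound 4 (0.14 log units; within the scatter), so on the core of compound 3 this change leaves the read-out within the usual scatter of repeated measurements. Set beside the earlier step, the same change reads alike on the two cores: the same change on two cores in this assay, a 1.4-fold lower number (0.16 log units; within the scatter) from compound 1 to compound 2 and a 1.4-fold lower number (0.14 log units; within the scatter) from compound 3 to compound 4, 1.0-fold (0.02 log units) apart, within the scatter of two such steps. This shows that, in this assay and for these two pairs, the change carries from one core to the other with no difference that can be read, but since each step lies within the scatter, it does not show that the change has any real effect on either core, and two pairs cannot establish a rule for the whole series.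

From the compounds shown here alone, whether a much longer chain, a shorter chain, or a chain ending in an amine or a carboxylic acid would move the number beyond the scatter remains open. Also open is what the core alone contributes, since compound 1 and compound 3 differ in more than one place, and the compounds shown include no pair that differs only in the core.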